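The source may report more compounds than this note shows. Statements on the series, on what has been measured and on what is new or still open speak of the compounds shown alone.

Measured in a functional assay on HUVEC cells (Homo sapiens) for inhibition, with a stated time of 4 days; a higher number here means a weaker inhibitor, a lower number a stronger inhibitor:
compound 1 `COc1ccc(C(C)=O)cc1COc1ccc(Cl)cc1`: 1200 nM
compound 2 `Cc1cc(OCc2cccc(C#N)c2)ccc1Cl`: 11000 nM
compound 3 `CCc1ccc(OC)c(COc2ccc(Cl)c(C)c2)c1`: 40000 nM

Of these three, compound 3 has the highest number and is the weakest inhibitor, with compound 2 and compound 1 both lying beyond the scatter from it. Compound 4 `COc1ccc(C(N)=O)cc1COc1ccc(Cl)c(C)c1` has carbamoyl in place of ethyl on an aromatic carbon, para to a methoxy group (carbamoyl in place of ethyl on an aromatic carbon). Within the data shown here, no step between measured compounds shows this change, so the evidence is indirect. Compound 1, which also holds a carbonyl group, gives 1200 nM in this assay. On that basis, a step to a lower number, beyond the scatter, is expected. The estimated step is a 13-fold lower number from compound 3 to compound 4 (1.12 log units; beyond the scatter). For compound 4 the expected value is 3000 nM, within an estimated range of 400 nM to 20000 nM.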

Compound 4, half-maximal inhibitory concentration: 640 nM
Estimate against measurement, compound 4: 4.7-fold (0.67 log units) above, and the stated range covers the measured number.
By their numbers in this assay, from the lowest: compounds 4 and 1 (each within the scatter of the next); then compound 2; then compound 3.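

At this aromatic carbon, para to a methoxy group, carbamoyl in place of ethyl gives a 63-fold lower number from compound 3 to compound 4 (1.80 log units; beyond the scatter) in this assay. This is the first change in a single place among these compounds, and it shows that this position alone can shift the number by a large step. Nothing here gives a cause for the step. From the compounds shown here alone, whether the carbonyl or the amide hydrogen carries this step stays open. So does how a carboxylic acid, a methyl ester or an amine would read at this position.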